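This account rests on a few compounds, and the source may have more. Where it says the series, first, only, none or still open, it means among the compounds named here.

Working notes on the cyanoaziridine urea series.

The series shares one core; compound 1 `CCCCNC(=O)N1CC1C#N` carries a butyl group on the amide-type nitrogen, compound 2 `CC(C)(C)NC(=O)N1CC1C#N` a tert-butyl group, and compound 3 `N#CC1CN1C(=O)Nc1cccc2ccccc12` a naphthyl group. In a functional assay on WiDr cells (Homo sapiens) for inhibition (on this read-out higher numbers stand for weaker inhibition and lower numbers for stronger inhibition), compound 1 gives 14000 nM, compound 2 gives 180000 nM, and compound 3 gives 2400 nM. Compound 2 stands at the top of the three numbers: the step of a 13-fold higher number from compound 1 to compound 2 (1.11 log units; beyond the scatter) is large, and compound 3 lies further still from compound 2.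

The next compound, compound 4 `CCNC(=O)N1CC1C#N`, differs from compound 2 by ethyl in place of tert-butyl on an amide-type nitrogen. Within the data shown here, the only step that bears on it is a 13-fold higher number from compound 1 to compound 2 (1.11 log units; beyond the scatter), where the branched group gave the higher number; going from tert-butyl back to a straight chain should undo much of that. For compound 4 the expectation is therefore a large move to a lower number in this assay, of about a 9.0-fold lower number from compound 2 to compound 4 (0.95 log units; beyond the scatter), landing near compound 1. The estimate for compound 4 in this assay is 20000 nM, within 6000 nM to 80000 nM.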

Compound 4, half-maximal inhibitory concentration: 4000 nM
Compound 4: the middle estimate sits 5.0-fold (0.70 log units) above what was measured; measured number outside the range, below it.
By their numbers in this assay, from the lowest: compounds 3 and 4 (each within the scatter of the next); then compound 1; then compound 2.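

In this assay, the step of a 45-fold lower number from compound 2 to compound 4 (1.65 log units; beyond the scatter) confirms that the tert-butyl group on this amide-type nitrogen carries a large penalty, now seen against a second straight chain. Among these compounds, the step of a 3.5-fold lower number from compound 1 to compound 4 (0.54 log units; beyond the scatter) adds something the earlier compounds could not show: the two straight chains also differ from each other, modestly but beyond the scatter, with ethyl giving the lower number, so chain length matters here as well as branching. No measurement bears on what lies behind either step.

The compounds shown leave open whether the number keeps falling with a methyl group or turns back up, and a propyl group would test whether the trend from butyl to ethyl is smooth. An isopropyl group would show how much branching the position takes before the number climbs towards that of compound 2.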